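The source may report more compounds than this note shows. Statements on the series, on what has been measured and on what is new or still open speak of the compounds shown alone.

Series notes. Three members of the series are measured in a functional assay on HeLa cells (Homo sapiens) for inhibition, read by CCK-8 assay, with a stated time of 72 h, tested at 2 uM; on this read-out lower numbers stand for less inhibition of growth and higher numbers for more inhibition of growth at the one concentration tested. Compound 1 `COc1ccc(SCc2ccc(C(=O)Nc3ccccc3N)cc2)cc1` gives 35%. Compound 2 `Nc1ccccc1NC(=O)c1ccc(CSc2cccc(F)c2)cc1` gives 22.5%. Compound 3 `CC(C)(C)c1ccc(SCc2ccc(C(=O)Nc3ccccc3N)cc2)cc1` gives 9.73%, the lowest of the three numbers; compound 2 sits nearest and compound 1 furthest, both gaps beyond the scatter.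

Two one-place steps are known. One is a number 12.5 percentage points lower from compound 1 to compound 2 (beyond the scatter), 3-fluorophenyl in place of 4-methoxyphenyl on a sulfur. The other is a number 25.3 percentage points lower from compound 1 to compound 3 (beyond the scatter), tert-butyl in place of methoxy on an aromatic carbon.

Compound 4 `CCc1ccc(SCc2ccc(C(=O)Nc3ccccc3N)cc2)cc1` is not yet measured. It differs from compound 3 in one place: ethyl in place of tert-butyl on an aromatic carbon The change sits on the aromatic carbon that carries the tert-butyl in compound 3, para to a large group. Among the measured compounds shown here, the step from compound 1 to compound 3 is the only measured step at this carbon and so bears most directly on it; its size was a number 25.3 percentage points lower from compound 1 to compound 3 (beyond the scatter). The step from compound 1 to compound 2 touched a different place and is only a weak guide. With methoxy on that carbon compound 1 gives 35%, with tert-butyl compound 3 gives 9.73%, and ethyl is neither. Compound 4 is therefore expected to land between those two numbers, a modest rise of a number 8.3 percentage points higher from compound 3 to compound 4 (within the scatter). The estimate for compound 4 in this assay is 18%, with a range from 6% to 32%.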

Compound 4, percent growth inhibition at one concentration: 30.8%
Estimate against measurement, compound 4: 12.8 percentage points below; the measured number falls inside the stated range.
By their numbers in this assay, from the lowest: compound 3; then compounds 2, 4 and 1 (each within the scatter of the next, the first and the last beyond it).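

In this assay, the low number of compound 3 is tied to tert-butyl itself and not to any carbon-linked group on this aromatic carbon: ethyl in its place gives a number 21.1 percentage points higher from compound 3 to compound 4 (beyond the scatter). Ethyl and methoxy are not separated at this carbon, with a number 4.2 percentage points lower from compound 1 to compound 4 (within the scatter), so losing the methoxy oxygen alone does not account for the earlier result with tert-butyl. The swap of the whole aryl group on the sulfur also leaves no readable difference, with a number 8.3 percentage points higher from compound 2 to compound 4 (within the scatter), so 4-ethylphenyl and 3-fluorophenyl cannot be ranked in this assay.

No supporting data on hand explain why tert-butyl stands apart from ethyl at this carbon. Still open, going by these compounds, is where between ethyl and tert-butyl the number starts to drop, which isopropyl or a longer chain such as n-butyl could show, and whether a hydroxyl, an amine or a carboxylic acid on the same carbon would stay level with ethyl and methoxy.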